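Diacylhydrazine series: aryl to chain exchange on one carbonyl

A few compounds are considered here, and "the series" means these few. Any claim that something is new, unique, unknown or untested is made for them only; others in the source may bear on it.

Measured so far in an assay on cells for agonist activity at ecdysone receptor (Bombyx mori), read by a luciferase reporter, with a stated time of 24 h; on this read-out lower numbers stand for an effect already at smaller amounts and higher numbers for an effect only at larger amounts of compound:
compound 1 `COc1cccc(C(=O)NN(C(=O)c2ccccc2Cl)C(C)(C)C)c1` gives 52.5 nM
compound 2 `COc1cccc(C(=O)NN(C(=O)c2cc(C)cc(C)c2)C(C)(C)C)c1` gives 66.1 nM
compound 3 `CCc1ccc(C(=O)NN(C(=O)CCC(C)C)C(C)(C)C)cc1` gives 832 nM

Compound 2 stands second highest of the three numbers. Its nearest neighbour is compound 1, the step of a 1.3-fold higher number from compound 1 to compound 2 (0.10 log units; within the scatter) lying within the scatter; compound 3 sits furthest away, beyond the scatter.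

Compound 4 `CCCCCC(=O)NN(C(=O)c1cc(C)cc(C)c1)C(C)(C)C` differs from compound 2 in one place: pentyl in place of 3-methoxyphenyl on a carbonyl carbon. Among the measured compounds shown here, the only measured step, a 1.3-fold higher number from compound 1 to compound 2 (0.10 log units; within the scatter), exchanges one aryl for another on a carbonyl and does not bear directly on an aryl to chain exchange. For the measured compounds named here, compound 3, which carries a chain on a carbonyl, shows a much higher number than compound 2, but the two differ in more than one place, so no single step is given. A higher number is expected for compound 4, a step of a 9.1-fold higher number from compound 2 to compound 4 (0.96 log units; beyond the scatter) in this assay. Compound 4 is estimated at 600 nM, in the range 150 nM to 2500 nM.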

Compound 4, half-maximal effective concentration: 79.4 nM
The estimate for compound 4 lay 7.6-fold (0.88 log units) above the measured number, outside the stated range (below it).
By their numbers in this assay, from the lowest: compounds 1, 2 and 4 (each within the scatter of the next); then compound 3.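

In this assay, pentyl in place of 3-methoxyphenyl on a carbonyl carbon gives a 1.2-fold higher number from compound 2 to compound 4 (0.08 log units; within the scatter) and so shows that an aromatic ring is not required at this place to keep the number within the scatter. For this one pair, a chain with fewer heavy atoms and no hydrogen-bond acceptor serves as well as the aryl group. No measured evidence bears on why the number holds.

As far as these compounds go, whether a longer chain or an amine on this carbonyl carbon would keep the number remains open. So does whether the same exchange gives the same result on the core of compound 1.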